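Swapping the nitrogen substituent of a chromanone sulfonamide

The source may hold more compounds than are shown below. What is called first, only, known or untested is meant among the compounds shown, and "the series" means these compounds.

Measured compounds:
compound 1, `CCc1ccc(N(CC(C)C)S(=O)(=O)c2ccc3c(c2)C(=O)CC(C(C)C2CCOCC2)O3)cc1`, 4.93
compound 2, `CCc1ccc(N(CC(C)C)S(=O)(=O)c2ccc3c(c2)C(F)CC(C2CCOCC2)O3)cc1`, 5.02
compound 3, `CC(C)CN(Cc1ccccc1C(F)(F)F)S(=O)(=O)c1ccc2c(c1)C(=O)CC(C1CCOCC1)O2`, 4.32

In a physicochemical assay for lipophilicity, at pH 7.4 (on this read-out higher numbers stand for higher lipophilicity and lower numbers for lower lipophilicity), compound 3 gives 4.32, the lowest of the three numbers; its gaps to compound 1 and to compound 2 both lie beyond the usual scatter of this assay. Compound 1 and compound 2 share a 4-ethylphenyl on the sulfonamide nitrogen, whereas compound 3 carries a 2-(trifluoromethyl)benzyl there.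

Compound 4, `CC(C)CN(c1ccc(F)cc1F)S(=O)(=O)c1ccc2c(c1)C(=O)CC(C1CCOCC1)O2`, has not yet been measured. It differs from compound 3 in one place: 2,4-difluorophenyl in place of 2-(trifluoromethyl)benzyl on a sulfonamide nitrogen. For the measured compounds named here, the entering group is smaller, with fewer heavy atoms and fewer fluorine atoms than the group that leaves, and no step between two measured compounds covers this exact change.

A modest downward step from compound 3 to compound 4 is expected in this assay, a number 0.17 log units lower from compound 3 to compound 4 (within the scatter), near the edge of the scatter. Compound 4 is therefore estimated at 4.15, within a range from 3.65 to 4.65.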

Compound 4, distribution coefficient: 3.62
For compound 4 the middle estimate is 0.53 log units above the measured one; measured number below the stated range.
By their numbers in this assay, from the lowest: compound 4; then compound 3; then compounds 1 and 2 (each within the scatter of the next).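

In this assay, exchanging the group on the sulfonamide nitrogen gives a number 0.70 log units lower from compound 3 to compound 4 (beyond the scatter). For the compounds shown here, this is the first step here in which the nitrogen substituent alone differs, and it shows that this read-out responds to a change at this place while the rest of the compound stays fixed. Nothing at hand accounts for the size of this step.

Going by these compounds alone, the single step changes the group from a benzyl to a phenyl and alters its fluorine content at the same time, so the contribution of each remains unresolved; an unsubstituted phenyl or a 2,4-difluorobenzyl on the same nitrogen would help to separate them. Going by these compounds, it also remains open whether the same swap would give a similar step on the cores of compound 1 and compound 2.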